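Working notes: thiophen-2-yl to phenyl at one site

The compounds below may be only part of what the source reports. "The series", "measured", "known", "first", "only" and "open" are said of these compounds alone.

Measured so far:
compound 1 `Cn1cccc1-c1cc(-c2cccs2)nc(N)c1C#N` — > 100000 nM
compound 2 `CC1CCCc2c1[nH]c(=O)c(C#N)c2-c1cccn1C` — > 100000 nM

In a functional assay on MCF7 cells (Homo sapiens) for inhibition, read by sulforhodamine B assay, with a stated time of 48 h (on this read-out higher numbers stand for weaker inhibition of growth and lower numbers for stronger inhibition of growth), compound 1 reaches only a limit of the assay, > 100000 nM. Compound 2 likewise gives only a limit, > 100000 nM. For the measured compounds named here, both values sit at the limit of > 100000 nM in this assay, at which 2 of the 2 values shown sit, so no measured step is available to place compound 1 beyond that limit. Compound 3 `Cn1cccc1-c1cc(-c2ccccc2)nc(N)c1C#N` differs from compound 1 by phenyl in place of thiophen-2-yl on an aromatic carbon. Given (the limit of > 100000 nM in this assay, at which 2 of the 2 values shown sit), the step in this assay is expected to be none beyond the scatter: a step that the limit leaves unreadable from compound 1 to compound 3. Compound 3 is estimated at 150000 nM, within 40000 nM to 500000 nM, most likely reported again only as a limit.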

Compound 3, concentration for 50% growth inhibition: > 100000 nM
Compound 3 gave a limit, no number; the forecaster's own chance of this, stated with the estimate: 80%; the middle value does not contradict the limit.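

Compound 1 and compound 3 both give limits, not numbers, so no step can be read between them: the limit of > 100000 nM in this assay, at which 3 of the 3 values shown sit.
The compounds shown leave open how phenyl and thiophen-2-yl compare wherever growth inhibition reaches a measurable number.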